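A Hydroxypiperidine Tail on the Shared Core

The compounds below may be only part of what the source reports. "The series", "measured", "known", "first", "only" and "open" are said of these compounds alone.

Compound 3 `O=C1c2c[n+]([O-])c3ccccc3c2C(=O)c2c1c1ccccc1n2CCN1CCCC1` gives the lowest of the three numbers in a functional assay on A-375 cells (Homo sapiens) for cytotoxicity, read by MTT assay, with a stated time of 72 h (a lower number here means a stronger inhibitor, a higher number a weaker inhibitor), at 430 nM. Compound 2 `O=C1c2c[n+]([O-])c3ccccc3c2C(=O)c2c1c1ccccc1n2Cc1cn(CC(O)CO)nn1` gives 440 nM, and the two lie within the scatter of each other, so neither can be called the stronger. Compound 1 `CN1CCN(CCCCCn2c3c(c4ccccc42)C(=O)c2c[n+]([O-])c4ccccc4c2C3=O)CC1` gives 1710 nM, with a 4.0-fold lower number from compound 1 to compound 3 (0.60 log units; beyond the scatter) and a 3.9-fold lower number from compound 1 to compound 2 (0.59 log units; beyond the scatter). Compound 4 `O=C1c2c[n+]([O-])c3ccccc3c2C(=O)c2c1c1ccccc1n2CCCN1CCC(O)CC1` differs from compound 3 by (4-hydroxypiperidin-1-yl)methyl in place of pyrrolidin-1-yl on a saturated chain carbon, two bonds along the chain from an aromatic nitrogen. Among the compounds with values here, two steps bear on this change: a 1.0-fold lower number from compound 2 to compound 3 (0.01 log units; within the scatter), and the larger 4.0-fold lower number from compound 1 to compound 3 (0.60 log units; beyond the scatter). Since compound 4 keeps a ring amine on a short chain, much as in the step from compound 2 to compound 3, no shift beyond the scatter is expected. Compound 4 is therefore estimated at 500 nM, within 250 nM to 1000 nM, which is expected to mean a 1.2-fold higher number from compound 3 to compound 4 (0.07 log units; within the scatter).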

Compound 4, half-maximal inhibitory concentration: 240 nM
Estimate against measurement, compound 4: 2.1-fold (0.32 log units) above; measured number below the stated range.
By their numbers in this assay, from the lowest: compounds 4, 3 and 2 (each within the scatter of the next); then compound 1.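

The larger 4-hydroxypiperidin-1-yl group on its propyl chain, which adds a hydroxyl, is accepted at this position: the swap for pyrrolidin-1-yl gives a 1.8-fold lower number from compound 3 to compound 4 (0.25 log units; within the scatter), and the swap for the triazole tail gives a 1.8-fold lower number from compound 2 to compound 4 (0.26 log units; within the scatter). Against the methylpiperazine tail, this assay shows a 7.1-fold lower number from compound 1 to compound 4 (0.85 log units; beyond the scatter), the widest step among these compounds. Nothing available explains these differences.

The hydroxyl, ring size and chain length all change at once here. A plain piperidin-1-yl or a morpholine on the same propyl chain would help separate them.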